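The source may report more compounds than this note shows. Statements on the series, on what has been measured and on what is new or still open speak of the compounds shown alone.

Measured so far:
compound 1 `CCn1c(CNc2ccccc2)nnc1SCC(=O)Nc1ccccc1` — > 1000 nM
compound 2 `CCn1c(CNc2ccccc2)nnc1SCc1nc2cc(F)ccc2o1` — > 1000 nM

In an assay on isolated protein for inhibition of long-chain fatty acid transport protein 1 (Homo sapiens) (a lower number here means a stronger inhibitor, a higher number a weaker inhibitor), compound 1 gives > 1000 nM, a limit of the assay rather than a number. Compound 2 likewise stops at a limit, > 1000 nM. Compound 1 therefore stands at the limit of > 1000 nM in this assay, at which 2 of the 2 values shown sit, with no measured value to set it apart.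

Compound 3 `CCn1nnc(-c2ccc(NC(=O)CSc3nnc(CNc4ccccc4)n3CC)cc2)n1` differs from compound 1 by 2-ethyl-2H-tetrazol-5-yl in place of hydrogen on an aromatic carbon, on an aromatic carbon of a six-membered aromatic ring of carbon only. Within the data shown here, with no measured step for comparison, the expected step that the limit leaves unreadable from compound 1 to compound 3 is small, with no clear direction beyond the scatter. Compound 3 is expected to give about 3000 nM, between 700 nM and 20000 nM, quite possibly again only a limit.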

Compound 3, half-maximal inhibitory concentration: > 1000 nM
Compound 3 was reported as a limit; the forecaster's own chance of this, stated with the estimate: 70%; the middle value lies beyond the limit too.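

In this assay, among these compounds, compound 1 and compound 3 both stop at a limit, so no step between them can be read: the limit of > 1000 nM in this assay, at which 3 of the 3 values shown sit. On these data alone, whether adding 2-ethyl-2H-tetrazol-5-yl changes inhibition at all, and in which direction, stays open.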